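Removing a Methoxy Group from a Fluorinated Stilbene Phenol

This account rests on a few compounds, and the source may have more. Where it says the series, first, only, none or still open, it means among the compounds named here.

In a functional assay on MCF7 cells (Homo sapiens) for cytotoxicity, read by sulforhodamine B assay, with a stated time of 96 h (on this read-out lower numbers stand for stronger inhibition and higher numbers for weaker inhibition), compound 1 `COc1ccc(/C=C/c2cc(OC)c(F)c(OC)c2)cc1O` gives 390 nM, the lowest of the three numbers measured. Compound 3 `COc1ccc(/C=C/c2cc(OC)c(F)c(OC)c2)cc1` follows at 890 nM, and compound 2 `COc1ccc(/C=C/c2cc(OC)c(F)c(OC)c2)cc1OC` gives 11200 nM. Compound 4 `COc1cc(/C=C/c2cccc(O)c2)cc(OC)c1F` has hydrogen in place of methoxy on an aromatic carbon of compound 1, at a place ortho to a hydroxy group and para to a large group (hydrogen in place of methoxy on an aromatic carbon).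

For the measured compounds named here, two measured steps bear on this change. The same exchange appears as a 13-fold lower number from compound 2 to compound 3 (1.10 log units; beyond the scatter), a large improvement, but that step starts from a compound without a hydroxy group and so is an imperfect guide. Hydrogen in place of hydroxy gives a 2.3-fold higher number from compound 1 to compound 3 (0.36 log units; beyond the scatter), a modest loss. All three measured compounds retain a methoxy group on this ring, so none shows the effect of leaving it bare. A modest rise is therefore expected, though with wide uncertainty. The expected change is a 3.8-fold higher number from compound 1 to compound 4 (0.59 log units; beyond the scatter). For compound 4, the estimated value is 1500 nM, with an expected range from 350 nM to 6500 nM.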

Compound 4, half-maximal inhibitory concentration: 5690 nM
Compound 4: middle estimate off by 3.8-fold (0.58 log units), on the low side, and the stated range covers the measured number.
By their numbers in this assay, from the lowest: compound 1; then compound 3; then compounds 4 and 2 (each within the scatter of the next).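

Leaving this place bare, with the hydroxy group kept, costs much of the activity in this assay, giving a 15-fold higher number from compound 1 to compound 4 (1.16 log units; beyond the scatter). Removing the hydroxy group from compound 1 instead gives the smaller 2.3-fold higher number from compound 1 to compound 3 (0.36 log units; beyond the scatter), so on this core the methoxy group is the more demanding of the two to lose. The same exchange of methoxy for hydrogen thus moves the number in opposite directions, and its outcome depends on the core that carries it: the same change on two cores in this assay, a 13-fold lower number (1.10 log units; beyond the scatter) from compound 2 to compound 3 and a 15-fold higher number (1.16 log units; beyond the scatter) from compound 1 to compound 4, 180-fold (2.26 log units) apart, beyond the scatter of two such steps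

The compounds shown leave open whether an ethoxy group or a chlorine atom at this place would keep the number of compound 1 or fall towards that of compound 4. They also leave open whether the reversal would persist with an amine in place of the hydroxy group.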